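Notes on the step from compound 1 to compound 4

This account rests on a few compounds, and the source may have more. Where it says the series, first, only, none or still open, it means among the compounds named here.

In an ADME assay on microsomes from liver (Homo sapiens) for metabolic stability, read by LC-MS, using NADPH, with stated times of 5 min and 30 min, tested at 1 uM (a higher number here means faster removal of the compound, a lower number slower removal), compound 1 `O=C1c2ccccc2CN1c1cnc(NCc2c(F)ccc3c2CCO3)n2cnnc12` gives 13 mL.min-1.g-1, the second highest of the three numbers. Compound 2 `Cc1ncccc1-c1cnc(NCc2c(F)ccc3c2CCO3)c2n[nH]c(=O)n12` gives 8 mL.min-1.g-1 and compound 3 `O=C1CCCN1c1cnc(NCc2c(F)ccc3c2CCO3)c2cn[nH]c(=O)c12` gives 23 mL.min-1.g-1, both within the scatter of compound 1. Compound 4 `COCCC(=O)Nc1cnc(NCc2c(F)ccc3c2CCO3)n2cnnc12` is not yet measured. Its difference from compound 1 is a group of 7 heavy atoms (4 carbon, 1 nitrogen, 2 oxygen; no ring) in place of a group of 10 heavy atoms (8 carbon, 1 nitrogen, 1 oxygen; one five-membered non-aromatic ring with 1 hetero atom, one six-membered aromatic ring of carbon only), on an aromatic carbon, with the ((2-methoxyethyl)carbonyl)amino group on an aromatic carbon. For the measured compounds named here, no measured pair isolates this change, so the expectation rests on the values of compound 1, compound 2 and compound 3 alone. The expected step is a 1.2-fold lower number from compound 1 to compound 4 (0.07 log units; within the scatter), with no shift beyond the scatter in either direction. For compound 4 the estimated value is 11 mL.min-1.g-1, with an expected range of 5 mL.min-1.g-1 to 25 mL.min-1.g-1.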

Compound 4, intrinsic clearance in microsomes: < 3 mL.min-1.g-1
Compound 4: a limit, no number (the forecaster's own chance of this, stated with the estimate: 8%); middle value at least 3.6-fold (0.56 log units) from the limit.
By their numbers in this assay, from the lowest: compounds 2, 1 and 3 (each within the scatter of the next, the first and the last beyond it). At a limit, below all of these: compound 4.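

In this assay, the ((2-methoxyethyl)carbonyl)amino group in place of the two-ring group of compound 1 gives an at least 4.3-fold lower number from compound 1 to compound 4 (0.63 log units; beyond the scatter), the only step shown at this position on the shared core and one beyond the scatter. Compound 4 gives a limit, not a number: the limit of < 3 mL.min-1.g-1 in this assay, at which 1 of the 4 values shown sits. This position therefore tolerates a ring-free group and can carry a large change in this read-out, with the full size of the step unknown.

The compounds shown leave open which part of the new group goes with the step. An acetylamino group, a longer ether chain or a free amine on the same carbon would separate these parts.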